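Methoxyphenyl for chlorophenyl: effect on cell cytotoxicity

The source may hold more compounds than are shown below. What is called first, only, known or untested is meant among the compounds shown, and "the series" means these compounds.

Measured compounds:
compound 1, `O=C(CN1CCN(c2cccc(Cl)c2)CC1)N1CCN(c2nnc(-c3ccccc3)c(-c3ccccc3)n2)CC1`: 56300 nM
compound 2, `COc1ccc(N2CCN(CC(=O)N3CCN(c4nnc(-c5ccccc5)c(-c5ccccc5)n4)CC3)CC2)cc1`: > 910000 nM (a limit)
compound 3, `Cc1ccc(-c2nnc(N3CCN(C(=O)CN4CCN(c5cccc(Cl)c5)CC4)CC3)nc2-c2ccc(C)cc2)cc1`: 797000 nM

In a functional assay on MCF7 cells (Homo sapiens) for cytotoxicity, read by MTT assay, with a stated time of 24 h (a higher number here means a weaker inhibitor, a lower number a stronger inhibitor), compound 1 gives 56300 nM. For compound 2 the value is a limit of the assay, (the limit of > 910000 nM in this assay, at which 1 of the 3 values shown sits). Compound 3 gives 797000 nM in this assay, the highest of the two numbers measured, and compound 3 sits well above compound 1.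

The change from compound 1 to compound 2 is 4-methoxyphenyl in place of 3-chlorophenyl on an amine nitrogen in a ring, and it made an at least 16-fold higher number from compound 1 to compound 2 (1.20 log units; beyond the scatter). How the core of compound 3 differs from the core of compound 1 is not broken down here. Compound 4, `COc1ccc(N2CCN(CC(=O)N3CCN(c4nnc(-c5ccc(C)cc5)c(-c5ccc(C)cc5)n4)CC3)CC2)cc1`, is made from compound 3 by the same change, (4-methoxyphenyl in place of 3-chlorophenyl on an amine nitrogen in a ring), at a place described in identical words.

A step of the same kind is expected in this assay, a 2.5-fold higher number from compound 3 to compound 4 (0.40 log units; beyond the scatter), because the same change gave an at least 16-fold higher number from compound 1 to compound 2 (1.20 log units; beyond the scatter). Since compound 3 already sits close to the limit, compound 4 is expected to be reported only as a limit; its estimated value is 2000000 nM, lying between 800000 nM and 8000000 nM.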

Compound 4, half-maximal inhibitory concentration: 53000 nM
Beside the measured number, compound 4's estimate is 38-fold (1.58 log units) above it; measured number below the stated range.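

In this assay, the change from 3-chlorophenyl to 4-methoxyphenyl did not carry over from one core to the other: the same change on two cores in this assay, an at least 16-fold higher number (1.20 log units; beyond the scatter) from compound 1 to compound 2 and a 15-fold lower number (1.18 log units; beyond the scatter) from compound 3 to compound 4, at least 240-fold (2.38 log units) apart, beyond the scatter of two such steps. Compound 2 is reported only as a limit, > 910000 nM. The new step, a 15-fold lower number from compound 3 to compound 4 (1.18 log units; beyond the scatter), runs in the opposite direction to the step on the core of compound 1, which shows that in these two pairs the outcome of this change depends on the core that carries it, but it does not show which part of the core is responsible or how the change would behave on any further core.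

The compounds shown leave open whether a 4-chlorophenyl or a 3-methoxyphenyl on the same amine nitrogen would follow either pair, which would separate the effect of the group from that of its position on the ring. As far as these compounds go, it also remains open whether a fluorine or a trifluoromethyl group on the core's outer phenyl rings would give the step seen on the core of compound 1 or the one seen on the core of compound 3.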